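Chain Extension in Two Series of Isothiocyanate-Bearing Anilinopyrimidines

This account rests on a few compounds, and the source may have more. Where it says the series, first, only, none or still open, it means among the compounds named here.

Measured compounds:
Compound 1, `CN(C)C(=O)c1cc2cnc(Nc3ccc(S(=O)(=O)NCCCCCN=C=S)cc3)nc2n1C1CCCC1`: 83.4%
Compound 2, `CN(C)C(=O)c1cc2cnc(Nc3ccc(S(=O)(=O)NCCCCCCN=C=S)cc3)nc2n1C1CCCC1`: 70.6%
Compound 3, `CN(C)C(=O)c1cc2cnc(Nc3ccc(C(=O)NCCCCN=C=S)cc3)nc2n1C1CCCC1`: 74.2%

Three compounds built on one shared core were tested in a functional assay on NCI-H1299 cells (Homo sapiens) for inhibition, read by CCK-8 assay, with a stated time of 72 h, tested at 10 uM; a higher number here means a stronger effect of the compound at the concentration tested, a lower number a weaker effect. Compound 1 gives 83.4% in this assay. Compound 2 differs from compound 1 by a group of 4 heavy atoms (2 carbon, 1 nitrogen, 1 sulfur; no ring) in place of a group of 3 heavy atoms (1 carbon, 1 nitrogen, 1 sulfur; no ring), on a saturated chain carbon, five bonds along the chain from a sulfonamide nitrogen. In this assay compound 2 gives 70.6%; the step of a number 12.8 percentage points lower from compound 1 to compound 2 (beyond the scatter) is the only one among these three that exceeds the scatter. Compound 3 differs from compound 1 in its core by a group of 10 heavy atoms (6 carbon, 2 nitrogen, 1 oxygen, 1 sulfur; no ring) in place of a group of 12 heavy atoms (6 carbon, 2 nitrogen, 2 oxygen, 2 sulfur; no ring), on an aromatic carbon. In this assay compound 3 gives 74.2%; the step of a number 9.2 percentage points lower from compound 1 to compound 3 (within the scatter) is within the scatter, so compound 1 and compound 3 cannot be ordered.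

Compound 4, `CN(C)C(=O)c1cc2cnc(Nc3ccc(C(=O)NCCCCCN=C=S)cc3)nc2n1C1CCCC1`, is not yet measured. It differs from compound 3 by a group of 4 heavy atoms (2 carbon, 1 nitrogen, 1 sulfur; no ring) in place of a group of 3 heavy atoms (1 carbon, 1 nitrogen, 1 sulfur; no ring), on a saturated chain carbon, four bonds along the chain from an amide-type nitrogen. This is the same kind of change as that from compound 1 to compound 2, but not the same: the group enters four bonds along the chain from an amide-type nitrogen rather than five bonds along the chain from a sulfonamide nitrogen. The change is seen twice among these compounds, once measured.

Because the step of a number 12.8 percentage points lower from compound 1 to compound 2 (beyond the scatter) was a modest drop beyond the scatter, compound 4 is expected to fall by a similar amount, estimated as a number 10.2 percentage points lower from compound 3 to compound 4 (beyond the scatter). The expectation rests on a single measured pair in a different core, so it is held loosely. Compound 4 is therefore estimated at 64%, within a range from 50% to 78%.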

Compound 4, a percentage reported as inhibition, at one concentration (the size of the read-out at that concentration, not a potency): 76.5%
Compound 4: middle estimate off by 12.5 percentage points, on the low side; the measured number falls inside the stated range.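

Lengthening the chain on the amide-linked compounds does not repeat what it did on the sulfonamide-linked pair: in this assay the step is a number 2.3 percentage points higher from compound 3 to compound 4 (within the scatter), and the two results differ by more than the scatter allows: the same change on two cores in this assay, a number 12.8 percentage points lower (beyond the scatter) from compound 1 to compound 2 and a number 2.3 percentage points higher (within the scatter) from compound 3 to compound 4, 15.1 percentage points apart, beyond the scatter of two such steps

The effect of this change therefore cannot be carried from one core to the other in this series, and the drop seen for compound 2 should be read as belonging to the sulfonamide pair alone. For the compounds shown here, this does not show why the two steps differ, nor whether the contrast is general, since each core supplies only one pair and the measurements come from a single concentration, without a potency. The step linking the two cores at this chain, a number 6.9 percentage points lower from compound 1 to compound 4 (within the scatter), leaves compound 1 and compound 4 unordered, so these data do not establish that either linkage is better.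

The compounds shown leave open how the read-out behaves with a longer chain on the amide series or a shorter chain on the sulfonamide series. They also leave open whether the isothiocyanate itself matters, which a compound carrying an amine or an acetamide at the chain end could test.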